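From methoxy to chloro: compound 2 and compound 4

The source may report more compounds than this note shows. Statements on the series, on what has been measured and on what is new or still open speak of the compounds shown alone.

Of the compounds shown here, three have been measured in a functional assay on HeLa cells (Homo sapiens) for antiproliferative activity, read by MTT assay, with a stated time of 72 h (a higher number here means a weaker inhibitor, a lower number a stronger inhibitor), so far. For the measured compounds named here, compound 1 (`COc1ncc(-c2ccc3c(c2)NC(=O)CO3)cc1NS(=O)(=O)c1ccc(F)cc1`) gives 7110 nM as the only actual number in the set. Compound 2 (`COc1ccc(N2C(=O)COc3ccc(-c4cnc5ccccc5c4)cc32)cc1`) gives > 40000 nM and this is a limit, not a number. Compound 3 (`O=C1COc2ccc(-c3cccc(NS(=O)(=O)c4ccc(F)cc4)c3)cc2N1C1CC1`) gives > 40000 nM and this is also a limit. The data therefore sit largely at one boundary: the limit of > 40000 nM in this assay, at which 2 of the 3 values shown sit.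

Compound 4 (`O=C1COc2ccc(-c3cnc4ccccc4c3)cc2N1c1ccc(Cl)cc1`) differs from compound 2 by chloro in place of methoxy on an aromatic carbon, which reads as 4-methoxyphenyl to 4-chlorophenyl. Going by the values given here, no measured pair shows this change. The expectation rests on compound 2 alone, with > 40000 nM as its limit. No shift beyond the scatter is expected in this assay and no direction can be favoured, so the estimated change is a number no higher from compound 2 to compound 4 (the limit leaves the size open) for now. For compound 4 the expected value is 40000 nM within an estimated range of 15000 nM to 100000 nM and a limit rather than a number is likely.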

Compound 4, half-maximal inhibitory concentration: > 40000 nM
Compound 4 was reported as a limit (the forecaster's own chance of this, stated with the estimate: 70%); the middle value sits exactly at the limit.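

Compound 2 and compound 4 are both limits, not numbers, in this assay, so no step can be read between them: the limit of > 40000 nM in this assay, at which 3 of the 4 values shown sit.

The compounds shown leave open whether 4-methoxyphenyl and 4-chlorophenyl differ at all in this assay.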